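Methoxy in place of chloro: compound 4 from compound 3

The source may report more compounds than this note shows. Statements on the series, on what has been measured and on what is new or still open speak of the compounds shown alone.

Measured so far in a functional assay on MCF7 cells (Homo sapiens) for inhibition, read by MTT assay; a higher number here means a weaker inhibitor, a lower number a stronger inhibitor:
compound 1, `CCOC(=O)/C(=C\c1ccc(B(O)O)cc1)C(=O)c1sc(Nc2ccccc2)nc1N(C)C`, gives 1500 nM
compound 2, `CCOC(=O)/C(=C\c1ccc(B(O)O)cc1)C(=O)c1sc(Nc2ccc(F)cc2)nc1-c1ccccc1`, gives 2710 nM
compound 3, `CCOC(=O)/C(=C\c1ccc(B(O)O)cc1)C(=O)c1sc(Nc2ccc(Cl)cc2)nc1N(C)C`, gives 240 nM

Compound 3 stands lowest of the three numbers in this assay; compound 1 sits nearest to it and compound 2 furthest, both gaps beyond the scatter. Compound 2 differs from compound 3 in more than one place, so only its value is noted here.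

Compound 4, `CCOC(=O)/C(=C\c1ccc(B(O)O)cc1)C(=O)c1sc(Nc2ccc(OC)cc2)nc1N(C)C`, takes the step (methoxy in place of chloro on an aromatic carbon). Among the measured compounds shown here, the only measured step that bears on this position is a 6.3-fold lower number from compound 1 to compound 3 (0.80 log units; beyond the scatter), which shows that a substituent para to a large group on this ring moves the number by a modest amount. For the measured compounds named here, no measured pair shows methoxy against chloro at this place, so the size of the new step is uncertain; the expectation is that some of the gain seen on going to chloro is kept, but not all. Compound 4 is therefore estimated at 600 nM, within 250 nM to 1500 nM, an expected step of a 2.5-fold higher number from compound 3 to compound 4 (0.40 log units; beyond the scatter).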

Compound 4, half-maximal inhibitory concentration: 2720 nM
For compound 4 the middle estimate is 4.5-fold (0.66 log units) below the measured one, outside the stated range (above it).
By their numbers in this assay, from the lowest: compound 3; then compounds 1, 2 and 4 (each within the scatter of the next).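

In this assay, among the compounds shown here, this position separates one substituent from another: replacing chloro with methoxy gives an 11-fold higher number from compound 3 to compound 4 (1.05 log units; beyond the scatter), a large step and the first direct comparison of two substituents here. Methoxy in place of hydrogen gives a 1.8-fold higher number from compound 1 to compound 4 (0.26 log units; within the scatter), so, unlike chloro with a 6.3-fold lower number from compound 1 to compound 3 (0.80 log units; beyond the scatter), methoxy shows no gain over the unsubstituted ring among these compounds. No available evidence accounts for the difference between chloro and methoxy.

On these data alone, with only hydrogen, chloro and methoxy compared on the same core, it remains open whether the gain is particular to chloro or would also appear with bromo, methyl or trifluoromethyl at this place. The fluoro group of compound 2 comes with a second structural difference, so its separate contribution cannot be read.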